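The source may report more compounds than this note shows. Statements on the series, on what has been measured and on what is new or still open speak of the compounds shown alone.

Measured in a functional assay on MGC-803 cells (Homo sapiens) for inhibition, read by MTT assay, with a stated time of 48 h; on this read-out lower numbers stand for stronger inhibition and higher numbers for weaker inhibition:
- compound 1 `C#CC(=O)N(Cc1ccc(OC)c(O)c1)c1cc(OC)c(OC)c(OC)c1`: 170 nM
- compound 2 `COc1ccc(CN(C(=O)CO)c2cc(OC)c(OC)c(OC)c2)cc1O`: 160 nM

Within the data shown here, at 160 nM, compound 2 cannot be told apart from the only other measured compound, as the two numbers lie within the scatter of each other.

Compound 3 `COc1ccc(CN(C(=O)CN=[N+]=[N-])c2cc(OC)c(OC)c(OC)c2)cc1O` carries azido in place of hydroxy on a saturated chain carbon bound to a carbonyl carbon.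

Among the measured compounds shown here, only one measured step bears on this change: a 1.1-fold lower number from compound 1 to compound 2 (0.03 log units; within the scatter), which swapped ethynyl for hydroxymethyl on a carbonyl carbon. For the measured compounds named here, no azido compound has been measured, so this is thin evidence. Because a 1.1-fold lower number from compound 1 to compound 2 (0.03 log units; within the scatter) stayed within the scatter, no step beyond the scatter is expected in this assay, in either direction.

Compound 3 is estimated at 200 nM, with an expected range of 70 nM to 600 nM.

This estimate means an expected 1.3-fold higher number from compound 2 to compound 3 (0.10 log units; within the scatter).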

Compound 3, half-maximal inhibitory concentration: 120 nM
The estimate for compound 3 lay 1.7-fold (0.22 log units) above the measured number, and the stated range covers the measured number.
By their numbers in this assay, from the lowest: compounds 3, 2 and 1 (each within the scatter of the next).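

In this assay, the azido group, with 3 heavy atoms and 0 hydrogen-bond donors, replaced hydroxy on a saturated chain carbon bound to a carbonyl carbon and gave a 1.3-fold lower number from compound 2 to compound 3 (0.12 log units; within the scatter). Azidomethyl in place of ethynyl on a carbonyl carbon gave a 1.4-fold lower number from compound 1 to compound 3 (0.15 log units; within the scatter), so ethynyl, hydroxymethyl and azidomethyl on this carbonyl carbon now stand within the scatter of one another, where the earlier compounds had offered only the first two. No measurement is available that would explain this result.

As far as these compounds go, whether an amine, a carboxylic acid or a longer chain at this place would also stay within the scatter remains open. So does whether these three groups would read alike in this assay on a core other than the one they share here.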